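Swapping the amide aryl group on a pyrazole urea

The source may report more compounds than this note shows. Statements on the series, on what has been measured and on what is new or still open speak of the compounds shown alone.

Of the compounds shown here, three share one core and have been tested in a functional assay on the whole organism (strain Swiss albino) for inhibition, with Mus musculus as the target, in the writhing test, with a stated time of 30 min, at a dose of 100 mg/kg; a lower number here means less inhibition, a higher number more inhibition at the dose given (going by the name of the read-out). Compound 3 `CCN1CCc2c(c(C(C)(C)C)nn2C(=O)Nc2c(C)cccc2C)C1` stands highest of the three, giving 73.7%. Compound 1 `CCN1CCc2c(c(C)nn2C(=O)Nc2c(C)cccc2C)C1` gives 60.5%, and compound 2 `CCN1CCc2c(c(C)nn2C(=O)Nc2ccc(C)cc2C)C1` gives 56.1%; these two values stand close together. For the measured compounds named here, the one step fully described, a number 13.2 percentage points higher from compound 1 to compound 3 (beyond the scatter), concerns a tert-butyl in place of a methyl on an aromatic carbon and is modest in size.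

Compound 4 `CCN1CCc2c(c(C(C)(C)C)nn2C(=O)Nc2ccc(Cl)cc2)C1` differs from compound 3 in another place: 4-chlorophenyl in place of 2,6-dimethylphenyl on an amide-type nitrogen. Going by the values given here, no measured step changes the aryl group on the amide nitrogen in this way, so the step from compound 1 to compound 3 does not bear directly on it, and the values of compound 1 and compound 2 only show that two different dimethylphenyl patterns give numbers close to each other. On this basis no step beyond the scatter is expected in this assay, but the range around the expectation must be wide. Compound 4 is therefore estimated to give 66%, with a range from 46% to 84%, meaning an expected step of a number 7.7 percentage points lower from compound 3 to compound 4 (within the scatter).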

Compound 4, a percentage reported as inhibition, in the whole organism at one dose (the size of the read-out at that dose, not a potency): 15.8%
Beside the measured number, compound 4's estimate is 50.2 percentage points above it; measured number outside the range, below it.
By their numbers in this assay, from the lowest: compound 4; then compounds 2 and 1 (each within the scatter of the next); then compound 3.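

In this assay, for the compounds shown here, the aryl group on the amide-type nitrogen proves to be a place where the number can move a long way: 4-chlorophenyl in place of 2,6-dimethylphenyl gives a large step (a number 57.9 percentage points lower from compound 3 to compound 4 (beyond the scatter)), whereas the earlier compounds offered only a close pair of dimethylphenyl patterns, with compound 1 (60.5%) and compound 2 (56.1%) within the scatter of each other. This step is also much bigger than the modest one seen on the aromatic carbon (a number 13.2 percentage points higher from compound 1 to compound 3 (beyond the scatter)), so in this small set the aryl group on the amide-type nitrogen matters more than the tert-butyl or methyl group. No measurement at hand accounts for the size of the new step.

The change alters both the kind of substituent and its place on the aromatic ring, and the compounds shown cannot separate the two, nor say whether 4-chlorophenyl would give a similar loss with methyl in place of tert-butyl. On these data alone, how an unsubstituted phenyl or a methoxyphenyl on this nitrogen would behave also remains open.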